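Series notes: from compound 1 to compound 4

The source may hold more compounds than are shown below. What is called first, only, known or untested is meant among the compounds shown, and "the series" means these compounds.

The shared core carries a carbon with a double bond to nitrogen, on which the aromatic ring is varied. Compound 1 `O=C(N/N=C/c1cccc(O)c1)c1cccnc1Nc1cccc(C(F)(F)F)c1` bears 3-hydroxyphenyl there; in a functional assay on the whole organism (strain Wistar) for inhibition, with Rattus norvegicus as the target, read by paw edema, with a stated time of 3 h, at a dose of 10 mg/kg by the intraperitoneal route (a lower number here means less inhibition, a higher number more inhibition at the dose given (going by the name of the read-out)), compound 1 gives 49%. Compound 2 `O=C(N/N=C/c1ccc(O)cc1)c1cccnc1Nc1cccc(C(F)(F)F)c1` gives 59.5% and compound 3 `O=C(N/N=C/c1ccc(O)c(O)c1)c1cccnc1Nc1cccc(C(F)(F)F)c1` gives 38.2%. Among these three numbers compound 1 stands second highest: the step of a number 10.5 percentage points higher from compound 1 to compound 2 (beyond the scatter) lies beyond the scatter, as does the step of a number 10.8 percentage points lower from compound 1 to compound 3 (beyond the scatter). Compound 3 also falls short of compound 2, a number 21.3 percentage points lower from compound 2 to compound 3 (beyond the scatter).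

Compound 4 `COc1ccc(/C=N/NC(=O)c2cccnc2Nc2cccc(C(F)(F)F)c2)cc1` has not yet been measured in this assay. It differs from compound 1 by 4-methoxyphenyl in place of 3-hydroxyphenyl on a carbon with a double bond to nitrogen. For the measured compounds named here, the measured step that bears on it most closely is the one from compound 1 to compound 2, a number 10.5 percentage points higher from compound 1 to compound 2 (beyond the scatter), a modest gain when the hydroxy sits on the 4-hydroxyphenyl rather than the 3-hydroxyphenyl. Going by the values given here, no measured pair shows methoxy in place of hydroxy, so that part of the change has no precedent. The expected step is therefore of roughly the size seen from compound 1 to compound 2, upward, though with wide uncertainty: a number 3 percentage points higher from compound 1 to compound 4 (within the scatter) is the estimate. Compound 4 is expected to give 52%, within a range from 38% to 66%.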

Compound 4, a percentage reported as inhibition, in the whole organism at one dose (the size of the read-out at that dose, not a potency): 26.5%
Compound 4: the middle estimate sits 25.5 percentage points above what was measured; measured number outside the range, below it.
By their numbers in this assay, from the lowest: compound 4; then compound 3; then compound 1; then compound 2.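

In this assay, methyl in place of hydrogen on the oxygen of the 4-hydroxyphenyl gives a number 33 percentage points lower from compound 2 to compound 4 (beyond the scatter), the largest step in the series, so the gain seen for the 4-hydroxyphenyl over the 3-hydroxyphenyl does not carry over to an aromatic ring with the same placement of oxygen once that oxygen bears a methyl. The 4-methoxyphenyl also gives a number 22.5 percentage points lower from compound 1 to compound 4 (beyond the scatter) and a number 11.7 percentage points lower from compound 3 to compound 4 (beyond the scatter), which leaves compound 4, the only one of the four without a hydrogen-bond donor on this ring, lowest of the set, although compound 3, with the most hydroxy groups, goes against any simple rise in the number with hydroxy count. The data at hand offer no measurement that explains these steps.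

Going by these compounds, whether the drop belongs to methyl in particular or would also come with a longer chain on the oxygen, such as ethyl, remains open, as does the effect of the same methyl on the 3-hydroxyphenyl of compound 1. On these data alone, it is also open whether an amine or a carboxylic acid in place of the hydroxy on this ring would keep the number of compound 2.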